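Replacing an aromatic ring with a branched alkene chain

The source may hold more compounds than are shown below. What is called first, only, known or untested is meant among the compounds shown, and "the series" means these compounds.

The step examined runs from compound 1, with the structure `CCC1(Cc2ccccc2)OS(=O)(=O)C=C1OCc1ccc(C)cc1`, to compound 4. In an ADME assay on HEL cells (Homo sapiens) for cytotoxicity, with a stated time of 3 days (a lower number here means that less compound is tolerated, a higher number that more compound is tolerated), compound 1 gives only a limit, >= 16000 nM. Compound 2, `CCC1(Cc2ccccc2)OS(=O)(=O)C=C1OCCCc1ccccc1`, differs from compound 1 in one place, phenethyl in place of 4-methylphenyl on a saturated chain carbon bound to an oxygen on an unsaturated carbon. In this assay compound 2 likewise gives only a limit, >= 20000 nM. Compound 3, `CC(C)C1(Cc2ccccc2)OS(=O)(=O)C=C1OCc1ccccc1`, also gives only a limit, >= 80000 nM. All three values are limits, so the step that the two limits leave unreadable from compound 1 to compound 2 cannot be read in size or direction, and the values of compound 3 set against the others show nothing more than that each sits at a limit, as the limit of >= 16000 nM in this assay, at which 1 of the 3 values shown sits, the limit of >= 20000 nM in this assay, at which 1 of the 3 values shown sits, and the limit of >= 80000 nM in this assay, at which 1 of the 3 values shown sits, record. Compound 4, `CCC1(Cc2ccccc2)OS(=O)(=O)C=C1OCC=C(C)C`, is changed from compound 1 as follows: 2-methylprop-1-en-1-yl in place of 4-methylphenyl on a saturated chain carbon bound to an oxygen on an unsaturated carbon. Going by the values given here, no measured step bears on this change in a readable way, so no step beyond the scatter is expected in either direction, and another limit close to that of compound 1 seems the likely outcome. Compound 4 is therefore expected to give about 18000 nM, estimated between 8000 nM and 50000 nM, which amounts to an expected step that the limit leaves unreadable from compound 1 to compound 4.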

Compound 4, minimum cytotoxic concentration: 400000 nM
The estimate for compound 4 lay 22-fold (1.35 log units) below the measured number, and the stated range ends below it.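

In this assay compound 4 gives 400000 nM. Compound 1 gives only a limit, >= 16000 nM. Compound 2 also gives only a limit, >= 20000 nM. The steps from these two compounds to compound 4 therefore cannot be read in size or direction. The compounds shown leave open whether 2-methylprop-1-en-1-yl in place of 4-methylphenyl or phenethyl changes the tolerated concentration at all.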